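A few compounds are considered here, and "the series" means these few. Any claim that something is new, unique, unknown or untested is made for them only; others in the source may bear on it.

Measured so far:
Compound 1 `COC(=O)c1ccc(CN2CCC[C@H](O[C@H](CO)c3cc(Cl)cc(Cl)c3)[C@@H]2c2ccccc2)c(C)c1` — 900 nM
Compound 2 `OC[C@@H](O[C@H]1CCCN(Cc2ncc[nH]2)[C@H]1c1ccccc1)c1cc(Cl)cc(Cl)c1` — 47000 nM
Compound 3 `Cc1nc(C(=O)O)ccc1CN1CCC[C@H](O[C@H](CO)c2cc(Cl)cc(Cl)c2)[C@@H]1c1ccccc1` — 370 nM

In an assay on isolated protein for activation of cGMP-dependent protein kinase 1 (Homo sapiens), read by ADP-Glo, with stated times of 30 min and 2 h, in the presence of a further agent that is not named here (a lower number here means that less compound is needed, a higher number that more compound is needed for the effect), compound 3 gives the lowest number of the three, with compound 1 nearest and compound 2 furthest away. Compound 4 `O=C(O)c1ccc(CN2CCC[C@H](O[C@H](CO)c3cc(Cl)cc(Cl)c3)[C@@H]2c2ccccc2)c([N+](=O)[O-])c1` differs from compound 3 in one place: a group of 12 heavy atoms (7 carbon, 1 nitrogen, 4 oxygen; one six-membered aromatic ring of carbon only) in place of a group of 10 heavy atoms (7 carbon, 1 nitrogen, 2 oxygen; one six-membered aromatic ring with 1 hetero atom), on a saturated chain carbon bound to an amine nitrogen in a ring. Of the steps seen so far, a 2.4-fold lower number from compound 1 to compound 3 (0.39 log units; beyond the scatter) is the one that touches this site while keeping a six-membered ring, and it was modest; a 130-fold lower number from compound 2 to compound 3 (2.10 log units; beyond the scatter) and a 52-fold higher number from compound 1 to compound 2 (1.72 log units; beyond the scatter) were large, but both involve the five-membered ring that compound 4 does not carry. A step from compound 3 to compound 4 of about a 1.4-fold higher number from compound 3 to compound 4 (0.13 log units; within the scatter) is therefore expected, within or near the scatter. For compound 4 a value of 500 nM is estimated, ranging from 150 nM to 1600 nM.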

Compound 4, half-maximal effective concentration: 520 nM
For compound 4 the middle estimate is 1.0-fold (0.02 log units) below the measured one; the measured number falls inside the stated range.
By their numbers in this assay, from the lowest: compounds 3, 4 and 1 (each within the scatter of the next, the first and the last beyond it); then compound 2.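

At this saturated chain carbon bound to an amine nitrogen in a ring, this assay does not separate 4-carboxy-2-nitrophenyl from the group of compound 3, with a 1.4-fold higher number from compound 3 to compound 4 (0.15 log units; within the scatter). The group of compound 1 also stays within the scatter of this new group, with a 1.7-fold lower number from compound 1 to compound 4 (0.24 log units; within the scatter). 1H-imidazol-2-yl stands apart, with a 90-fold lower number from compound 2 to compound 4 (1.96 log units; beyond the scatter), so a six-membered aromatic ring of carbon only can carry this result as well as one with a hetero atom.

Nothing available explains these numbers. Open, on these data alone, is what a plain 4-carboxyphenyl group, or an amide in place of the carboxylic acid, would give at this place.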